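The source may hold more compounds than are shown below. What is called first, only, known or untested is meant among the compounds shown, and "the series" means these compounds.

Measured so far in an assay on cells for inhibition of HSP60/HSP10 (Homo sapiens), with a stated time of 60 min; a higher number here means a weaker inhibitor, a lower number a stronger inhibitor: compound 1 `O=[N+]([O-])c1cc(S(=O)(=O)Nc2ccc(-c3nc4ccccc4o3)cc2)ccc1Cl` gives 17000 nM; compound 2 `N#Cc1ccc(S(=O)(=O)Nc2ccc(-c3nc4cc(NS(=O)(=O)c5ccc(C#N)cc5)ccc4o3)cc2)cc1` gives 49000 nM. Compound 3 `O=S(=O)(Nc1ccc2oc(-c3ccccc3)nc2c1)c1ccc(Cl)c(Cl)c1` reaches only a limit of this assay, > 100000 nM, and not a number. Among the two numbers, compound 1 has the lowest; compound 2 sits at a higher number, beyond the scatter. The limit is the limit of > 100000 nM in this assay, at which 1 of the 3 values shown sits.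

Compound 4 `O=S(=O)(Nc1ccc(-c2nc3ccccc3o2)cc1)c1ccc(Cl)c(Cl)c1` has not yet been measured. It differs from compound 1 in one place: chloro in place of nitro on an aromatic carbon. For the measured compounds named here, no measured pair shows this change alone, so its size is not known from the data. A small weakening, barely beyond the scatter, is expected, so that the estimated step is a 1.5-fold higher number from compound 1 to compound 4 (0.17 log units; within the scatter). Compound 4 is therefore expected at 25000 nM, within 8000 nM to 80000 nM.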

Compound 4, half-maximal inhibitory concentration: 25000 nM
For compound 4 middle estimate and measured number coincide at the digits printed; low and high end bracket the measured number.
By their numbers in this assay, from the lowest: compounds 1, 4 and 2 (each within the scatter of the next, the first and the last beyond it). At a limit, above all of these: compound 3.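

In this assay, the step for chloro in place of nitro on this aromatic carbon, ortho to a chloro group, is a 1.5-fold higher number from compound 1 to compound 4 (0.17 log units; within the scatter). The two groups thus cannot be told apart at this position, so the nitro group and its hydrogen-bond acceptors are not needed to keep a value at this level. Nothing shown gives a cause for this result.

On these data alone, whether an amine or a carboxylic acid at this position would fit equally well stays open. So does whether the same change would give a similar step on another core.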